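Chain saturation in two urea pairs

The compounds below may be only part of what the source reports. "The series", "measured", "known", "first", "only" and "open" are said of these compounds alone.

The study compares four ureas that share a long aliphatic chain on one nitrogen and a substituted aryl group on the other. Compound 1 `CCCCCCCC/C=C\CCCCCCCCNC(=O)Nc1c(C)cccc1Cl` and compound 3 `CCCCCCCCCCCCCCCCCCNC(=O)Nc1c(C)cccc1Cl` differ only by decyl in place of dec-1-en-1-yl on a saturated chain carbon, eight bonds along the chain from an amide-type nitrogen. In an assay on microsomes from intestinal mucosa for inhibition of acyl-CoA:cholesterol acyltransferase (Oryctolagus cuniculus) (on this read-out higher numbers stand for weaker inhibition and lower numbers for stronger inhibition), compound 1 gives 180 nM, while compound 3 gives 1100 nM, so the change costs a 6.1-fold higher number from compound 1 to compound 3 (0.79 log units; beyond the scatter).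

Compound 2 `CCCCCCCC/C=C\CCCCCCCCNC(=O)Nc1c(C(C)C)cccc1C(C)C` carries the unsaturated chain on a different core; the difference between the core of compound 1 and the core of compound 2 is not broken down here. In this assay compound 2 gives 28 nM, the lowest of the three measured numbers and beyond the scatter from both compound 1 and compound 3.

Compound 4 `CCCCCCCCCCCCCCCCCCNC(=O)Nc1c(C(C)C)cccc1C(C)C` has not been measured. It stands to compound 2 exactly as compound 3 stands to compound 1: the change is decyl in place of dec-1-en-1-yl on a saturated chain carbon, eight bonds along the chain from an amide-type nitrogen, the same change made at the same place. Within the data shown here, the only guide is the measured pair, in which the saturated chain gave the higher number. On that basis compound 4 is expected to show a 6.1-fold higher number from compound 2 to compound 4 (0.78 log units; beyond the scatter) in this assay, mirroring the step seen from compound 1 to compound 3. Compound 4 is therefore estimated at 170 nM, with a range of 60 nM to 500 nM.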

Compound 4, half-maximal inhibitory concentration: 48 nM
For compound 4 the middle estimate is 3.5-fold (0.55 log units) above the measured one; the whole stated range lies above it.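

On the core of compound 2, in this assay, putting decyl in place of dec-1-en-1-yl gives a 1.7-fold higher number from compound 2 to compound 4 (0.23 log units; within the scatter), so on this core the measurement does not separate the saturated chain from the unsaturated one. The change therefore did not carry over from one core to the other at the size seen in the first pair, and the two steps differ by more than repeated measurement would explain: the same change on two cores in this assay, a 6.1-fold higher number (0.79 log units; beyond the scatter) from compound 1 to compound 3 and a 1.7-fold higher number (0.23 log units; within the scatter) from compound 2 to compound 4, 3.6-fold (0.55 log units) apart, beyond the scatter of two such steps These two pairs show that the step depends on the core in this series, but they do not show which part of the core matters, since the two cores differ in more than one group, and they cannot say how the step would behave on any third core.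

The compounds shown leave open whether a core carrying one isopropyl group and one chlorine would give the larger step, the smaller one or something in between. They also leave open how the two cores would respond to a longer chain, or to a chain with a triple bond in place of the double bond.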